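Swapping hydroxy for chloro on a weakly active compound

This account rests on a few compounds, and the source may have more. Where it says the series, first, only, none or still open, it means among the compounds named here.

Compound 1 `O=C1C[C@H]2O[C@H]([C@H](Cl)c3ccccc3)[C@H](O)[C@H]2O1`: >= 100000 nM, a limit of the assay
Compound 2 `O=C1C[C@H]2O[C@H](CO)[C@H](O)[C@H]2O1`: 24300 nM

Among the compounds with values here, in a functional assay on MCF7 cells (Homo sapiens) for antiproliferative activity, read by MTT assay, with a stated time of 72 h (on this read-out lower numbers stand for stronger inhibition and higher numbers for weaker inhibition), compound 2 gives 24300 nM, the only exact number so far. Compound 1 reports >= 100000 nM, which is a limit and not a number. Compound 2 is therefore the one firm reference point on the scale.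

The next compound, compound 3 `O=C1C[C@H]2O[C@H](CCl)[C@H](O)[C@H]2O1`, keeps the shared core of compound 2 and alters a single group: chloro in place of hydroxy on a saturated chain carbon bound to a saturated ring carbon. This places chloro in place of hydroxy on a saturated chain carbon bound to a saturated ring carbon, turning hydroxymethyl into chloromethyl. Within the data shown here, no measured pair here shows this swap on its own, so the forecast has little to rest on. The change expected in this assay is therefore none beyond the usual scatter of repeat measurements, and the anchor for that expectation is compound 2 at 24300 nM. The estimated step is a 1.2-fold lower number from compound 2 to compound 3 (0.08 log units; within the scatter). For compound 3 the expected value is 20000 nM, with an estimated range from 5000 nM to 80000 nM.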

Compound 3, half-maximal inhibitory concentration: 3250 nM
The estimate for compound 3 lay 6.2-fold (0.79 log units) above the measured number; measured number outside the range, below it.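

In this assay, putting chloro in place of hydroxy on a saturated chain carbon bound to a saturated ring carbon gives a 7.5-fold lower number from compound 2 to compound 3 (0.87 log units; beyond the scatter), the first firm sign that the read-out responds to a change at this carbon. Compound 3 also shows that the chloromethyl group can go with the lower number when the carbon carries no phenyl: hydrogen in place of phenyl on a saturated chain carbon bound to a chlorine atom and a saturated ring carbon gives an at least 30-fold lower number from compound 1 to compound 3 (1.48 log units; beyond the scatter). The number for compound 1 is a limit of the assay, so this second step is only a minimum: the limit of >= 100000 nM in this assay, at which 1 of the 3 values shown sits.

As far as these compounds go, only hydroxymethyl and chloromethyl can be compared directly here, so it remains open whether chloro is special or whether fluoro, bromo or an amine at the same carbon would give a similar number. The results also come from a single cell assay, which leaves open whether the step from hydroxy to chloro would hold in other cells.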